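The source may hold more compounds than are shown below. What is called first, only, known or untested is meant among the compounds shown, and "the series" means these compounds.

Working notes on the series

Three salicylanilides have been measured in a functional assay on NALM-6 cells (Homo sapiens) for cytotoxicity, read by luminescence and CellTiter-Glo, with a stated time of 3 days; on this read-out higher numbers stand for weaker inhibition and lower numbers for stronger inhibition. Compound 1 `O=C(Nc1ccc(OC(F)(F)F)cc1)c1cc(F)ccc1O` gives 1210 nM, compound 2 `O=C(Nc1ccc(C(F)(F)F)cc1)c1cc(F)ccc1O` gives 2090 nM, and compound 3 `O=C(Nc1cccc(C(F)(F)F)c1)c1cc(F)ccc1O` gives 1800 nM. Among the measured compounds shown here, the three values sit close together, and no step between any two of them goes beyond the scatter.

Compound 2 and compound 1 differ by one change, (trifluoromethoxy in place of trifluoromethyl on an aromatic carbon), and that change gives a 1.7-fold lower number from compound 2 to compound 1 (0.24 log units; within the scatter). Compound 3 shares all its atoms with compound 2, but they are joined differently; the difference between the two cores is not broken down here.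

Compound 4 `O=C(Nc1cccc(OC(F)(F)F)c1)c1cc(F)ccc1O` is not yet measured. It arises from compound 3 by trifluoromethoxy in place of trifluoromethyl on an aromatic carbon. For the measured compounds named here, this is the same kind of change as the one from compound 2 to compound 1, but the surroundings differ: in compound 1 the group sits para to a large group, whereas in compound 4 it sits meta to a large group. Going by the values given here, only one earlier example of the change exists, and it stayed within the scatter, so the expectation for compound 4 rests on a single small step.

Among the compounds with values here, for compound 4 the expected step is a 1.6-fold lower number from compound 3 to compound 4 (0.21 log units; within the scatter) because of a 1.7-fold lower number from compound 2 to compound 1 (0.24 log units; within the scatter), which is the only precedent for the change. Compound 4 is therefore estimated at 1100 nM in this assay, with a likely range from 500 nM to 2500 nM.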

Compound 4, half-maximal inhibitory concentration: 1370 nM
Beside the measured number, compound 4's estimate is 1.2-fold (0.10 log units) below it; measured number inside the range.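

In this assay, trifluoromethoxy in place of trifluoromethyl on an aromatic carbon gives a 1.3-fold lower number from compound 3 to compound 4 (0.12 log units; within the scatter), a second small step for this change. Set beside the first example, the new step cannot be told apart from it: the same change on two cores in this assay, a 1.7-fold lower number (0.24 log units; within the scatter) from compound 2 to compound 1 and a 1.3-fold lower number (0.12 log units; within the scatter) from compound 3 to compound 4, 1.3-fold (0.12 log units) apart, within the scatter of two such steps. So far the change carries from one core to the other without a detectable difference, but this does not show that it truly moves the number on either core, as each step lies within the scatter, and two closely related cores are too few to support a rule for the wider series.

The four compounds keep the hydroxyl, the fluorine and the amide of the shared core constant and vary only the trifluoromethyl or trifluoromethoxy group and where it sits, so they leave open how much of the number in this assay depends on any of those shared features. Also open, going by these compounds, is whether a different group at that place, such as a nitrile, an amine or a carboxylic acid, would give a step beyond the scatter.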